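Ethoxy step from compound 1 to compound 4

A few compounds are considered here, and "the series" means these few. Any claim that something is new, unique, unknown or untested is made for them only; others in the source may bear on it.

In a functional assay on HaCaT cells (Homo sapiens) for antiproliferative activity, read by sulforhodamine B assay, with a stated time of 3 days (a lower number here means a stronger inhibitor, a higher number a weaker inhibitor), compound 1 `COC(=O)c1cc(CCc2ccccc2OC)ccc1O` gives 20000 nM. Compound 2 `COC(=O)c1cc(CCc2ccc(OC)cc2OC)ccc1O` gives 19000 nM, level with compound 1 within the scatter, while compound 3 `COC(=O)c1cc(CCc2c(OC)cccc2OC)ccc1O` gives 110 nM. Compound 1 therefore stands at the weak end of the three numbers, alongside compound 2 and far from compound 3.

Compound 4 `CCOc1ccc(OC)c(CCc2ccc(O)c(C(=O)OC)c2)c1` differs from compound 1 by ethoxy in place of hydrogen on an aromatic carbon, meta to a large group and para to a methoxy group.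

Among the compounds with values here, two measured steps bear on this change, both with methoxy in place of hydrogen on an aromatic carbon. One is a 1.1-fold lower number from compound 1 to compound 2 (0.02 log units; within the scatter), and the other is the large 180-fold lower number from compound 1 to compound 3 (2.26 log units; beyond the scatter). The same kind of change has thus given no visible shift in one case and a very large drop in the other. Neither step introduces ethoxy or uses the carbon substituted in compound 4, so the data do not settle which precedent applies. Most weight goes to a small shift, with some allowance for a larger drop.

The estimated step in this assay is a 2.5-fold lower number from compound 1 to compound 4 (0.40 log units; beyond the scatter), towards a lower number. For compound 4 the expected value is 8000 nM, with an estimated range from 600 nM to 30000 nM.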

Compound 4, half-maximal inhibitory concentration: 540 nM
For compound 4 the middle estimate is 15-fold (1.17 log units) above the measured one; measured number below the stated range.
By their numbers in this assay, from the lowest: compound 3; then compound 4; then compounds 2 and 1 (each within the scatter of the next).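

In this assay the ethoxy change gives a 37-fold lower number from compound 1 to compound 4 (1.57 log units; beyond the scatter) and so marks the aromatic carbon meta to a large group and para to a methoxy group as a place where substitution on the core of compound 1 goes with a large fall in the number. The series now has two single changes with a large step, and compound 3 is the other, with a 180-fold lower number from compound 1 to compound 3 (2.26 log units; beyond the scatter) as its methoxy precedent. Compound 2 goes against any rule that adding an alkoxy group to this ring is enough, since a 1.1-fold lower number from compound 1 to compound 2 (0.02 log units; within the scatter) stays within the scatter, so the outcome depends on the carbon substituted, at least among these compounds. No measurement to hand accounts for any of these steps.

As far as these compounds go, it remains open whether the step belongs to ethoxy itself or to any group at this carbon, and methoxy, a longer chain such as propoxy, or an amine there would separate those readings. From the compounds shown here alone, it is also open whether the ethoxy change and the change in compound 3 would add up when carried together on the core.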